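Swapping Methyl for Nitro in Compound 4

The source may hold more compounds than are shown below. What is called first, only, known or untested is meant among the compounds shown, and "the series" means these compounds.

Compound 1 `O=C(N/N=C/c1cc(I)cc(I)c1O)c1ccc(F)cc1` gives 12100 nM in a functional assay on HepG2 cells (Homo sapiens) for cytotoxicity, with a stated time of 24 h; a higher number here means a weaker inhibitor, a lower number a stronger inhibitor. Compound 2 `O=C(N/N=C/c1cc(I)cc(I)c1O)c1ccc([N+](=O)[O-])cc1` gives 24700 nM. Compound 3 `Cc1ccc(C(=O)N/N=C/c2cc(I)c(O)c(I)c2)cc1` gives > 100000 nM.

For compound 3 that value is a limit of the assay and not a number (the limit of > 100000 nM in this assay, at which 1 of the 3 values shown sits), so compound 3 stands at the weak end of what the assay can report. Compound 4 `O=C(N/N=C/c1cc(I)c(O)c(I)c1)c1ccc([N+](=O)[O-])cc1` differs from compound 3 in one place: nitro in place of methyl on an aromatic carbon. Among the compounds with values here, the only measured step that brings in a nitro group is a 2.0-fold higher number from compound 1 to compound 2 (0.31 log units; beyond the scatter), where nitro replaced fluoro rather than methyl. The step from compound 3 to compound 4 is therefore expected to be small, a step that the limit leaves unreadable from compound 3 to compound 4, and likely to end again at a limit. For compound 4 the estimate is 150000 nM, between 40000 nM and 600000 nM.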

Compound 4, half-maximal inhibitory concentration: 92100 nM
Compound 4: middle estimate off by 1.6-fold (0.21 log units), on the high side; low and high end bracket the measured number.
By their numbers in this assay, from the lowest: compound 1; then compound 2; then compound 4. At a limit, above all of these: compound 3.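

Nitro in place of methyl, on this aromatic carbon para to a large group, gives a number the assay can read, where the methyl compound gave none. The step is an at least 1.0-fold lower number from compound 3 to compound 4 (0.03 log units; that floor lies within the scatter), and as a floor it leaves the true size of the change unknown. Compound 3 remains a limit and not a number: the limit of > 100000 nM in this assay, at which 1 of the 4 values shown sits.

As far as these compounds go, whether an amine or a carboxylic acid on this same carbon would give a lower number stays open. So does how methyl would compare with nitro on the shared core of compound 1 and compound 2.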